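Methyl in place of methoxy on a long-lived compound

This account rests on a few compounds, and the source may have more. Where it says the series, first, only, none or still open, it means among the compounds named here.

Measured in an ADME assay for pharmacokinetics, at pH 7.4; on this read-out lower numbers stand for a shorter-lived compound and higher numbers for a longer-lived compound:
- compound 1 `COc1ccnc(C[S+]([O-])c2nc3cc(OC(F)F)ccc3[nH]2)c1`: 51 h
- compound 2 `COc1ccnc(C[S+]([O-])c2nc3cc(OCC(F)(F)F)ccc3[nH]2)c1OC`: > 200 h

In this assay compound 2 stands at > 200 h, and this is a limit of the assay, not a number.

Compound 3 `COc1ccnc(C[S+]([O-])c2nc3cc(OCC(F)(F)F)ccc3[nH]2)c1C` differs from compound 2 in one place, with methyl in place of methoxy on an aromatic carbon. The change lies two atoms from the ring nitrogen.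

Among the compounds with values here, no measured pair isolates this change, since compound 1 and compound 2 differ in more than one place. A step towards a shorter-lived compound, beyond the usual scatter, is nevertheless expected, because compound 1 at 51 h shows that a related structure can give a number well within the range of this assay.

The estimated change is an at least 2.8-fold lower number from compound 2 to compound 3 (0.45 log units; beyond the scatter). For compound 3 the expected value is 70 h, with an estimated range from 25 h to 180 h.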

Compound 3, half-life in the ADME assay: 5 h
Compound 3: middle estimate off by 14-fold (1.15 log units), on the high side, and the stated range ends above it.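

Within the data shown here, at this position, two atoms from the ring nitrogen, methyl in place of methoxy gives in the ADME assay an at least 40-fold lower number from compound 2 to compound 3 (1.60 log units; beyond the scatter), with compound 3 at 5 h; this is the first step here that isolates a single change and shows that this one place alone can carry a large step. In the ADME assay compound 2 stands at > 200 h, a limit of the assay and not a number, so this step gives only a bound on the size of the change: the limit of > 200 h in the ADME assay, at which 1 of the 3 values shown sits. In a physicochemical assay for acid dissociation, compound 2 gives 8.52 and compound 3 gives 8.51; the same change gives a number 0.01 log units lower from compound 2 to compound 3 (within the scatter), so the large step in half-life comes without a difference in acid dissociation beyond the scatter.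

The compounds shown do not tell whether the step comes from methoxy leaving or from methyl entering, and an ethyl group or a chlorine atom at this place could help to separate the two. As far as these compounds go, whether the same change acts alike on the core of compound 1 also stays open.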